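The source may hold more compounds than are shown below. What is called first, only, known or untested is meant among the compounds shown, and "the series" means these compounds.

In a functional assay on A-375 cells (Homo sapiens) for antiproliferative activity, read by MTT assay, with a stated time of 72 h (a lower number here means a stronger inhibitor, a higher number a weaker inhibitor), compound 1 (`COc1ncc(-c2ccc3c(c2)N(c2ccc(C)cc2)C(=O)CO3)cc1NS(=O)(=O)c1ccc(F)cc1`) gives 12900 nM. Compound 3 (`COc1ncc(-c2ccc3c(c2)N(c2ccccc2)C(=O)CO3)cc1NS(=O)(=O)c1ccc(F)cc1`) gives 15200 nM, and compound 2 (`COc1ncc(-c2ccc3c(c2)NC(=O)CO3)cc1NS(=O)(=O)c1ccc(F)cc1`) gives 26300 nM. Compound 1 thus shares the top of this small series with compound 3, as shown by a 1.2-fold higher number from compound 1 to compound 3 (0.07 log units; within the scatter), and it separates only modestly from compound 2, with a 2.0-fold higher number from compound 1 to compound 2 (0.31 log units; beyond the scatter). The next compound, compound 4 (`Cc1ccc(N2C(=O)COc3ccc(-c4cnc(Cl)c(NS(=O)(=O)c5ccc(F)cc5)c4)cc32)cc1`), carries a change elsewhere in the molecule: chloro in place of methoxy on an aromatic carbon, with chloro in place of methoxy on an aromatic carbon of the six-membered aromatic ring with 1 nitrogen. Within the data shown here, no measured step touches that place. The three available steps, including a 1.7-fold lower number from compound 2 to compound 3 (0.24 log units; within the scatter), all concern the substituent on the amide-type nitrogen, so they show only how little this series has moved so far. Among the measured compounds shown here, with no direct precedent, no clear direction can be argued, and no shift beyond the scatter is expected, the estimate being a 1.1-fold higher number from compound 1 to compound 4 (0.04 log units; within the scatter). Compound 4 is expected at about 14000 nM, with an estimated range from 5000 nM to 40000 nM.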

Compound 4, half-maximal inhibitory concentration: 38900 nM
For compound 4 the middle estimate is 2.8-fold (0.44 log units) below the measured one; the measured number falls inside the stated range.
By their numbers in this assay, from the lowest: compounds 1, 3, 2 and 4 (each within the scatter of the next, the first and the last beyond it).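

Among these compounds, the methoxy group on the aromatic carbon next to the ring nitrogen, ortho to the ((4-fluorophenyl)sulfonyl)amino group, is the first place outside the amide-type nitrogen to be probed, and the number responds to a change there. In this assay, chloro in place of methoxy gives a 3.0-fold higher number from compound 1 to compound 4 (0.48 log units; beyond the scatter) and so a weaker inhibitor, a modest step. Like the loss of the 4-methylphenyl group, with a 2.0-fold higher number from compound 1 to compound 2 (0.31 log units; beyond the scatter), this single replacement lies beyond the scatter, so the series is sensitive at more than one place, although no measurement given here explains this shift. With only this one pair, the compounds shown leave open whether the step reflects losing methoxy or gaining chloro. They also leave open how hydrogen, an amine or ethoxy would read on this carbon, and whether the step holds with phenyl or hydrogen on the amide-type nitrogen.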